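The compounds below may be only part of what the source reports. "The series", "measured", "known", "first", "only" and "open" are said of these compounds alone.

Measured so far:
- compound 1 `CC(C)COc1nc(C(C)(C)C)ccc1CNC(=O)C(C)c1ccc(NS(C)(=O)=O)c(F)c1`: 0.6 nM
- compound 2 `CCCCSc1nc(C(C)(C)C)ccc1CNC(=O)C(C)c1ccc(NS(C)(=O)=O)c(F)c1`: 3.2 nM

In an assay on cells for antagonist activity at transient receptor potential cation channel subfamily V member 1 (Homo sapiens), read by FLIPR and calcium flux, with a stated time of 6 min (on this read-out lower numbers stand for stronger inhibition and higher numbers for weaker inhibition), compound 1 gives the lower of the two numbers; its nearest neighbour is compound 2, with a 5.3-fold higher number from compound 1 to compound 2 (0.73 log units; beyond the scatter), a change from isobutoxy to butylsulfanyl. Compound 3 `CC(C(=O)NCc1ccc(C(C)(C)C)nc1SCc1ccccc1)c1ccc(NS(C)(=O)=O)c(F)c1` carries the change (benzylsulfanyl in place of isobutoxy on an aromatic carbon). Going by the values given here, the only step bearing on it is the one from compound 1 to compound 2, which also replaces isobutoxy with a sulfanyl group and raised the number modestly. A similar modest rise is therefore expected for compound 3, about a 5.0-fold higher number from compound 1 to compound 3 (0.70 log units; beyond the scatter). Compound 3 is estimated at 3 nM, with a range from 1 nM to 10 nM.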

Compound 3, inhibition constant: 4 nM
Compound 3: the middle estimate sits 1.3-fold (0.12 log units) below what was measured, and the stated range covers the measured number.
By their numbers in this assay, from the lowest: compound 1; then compounds 2 and 3 (each within the scatter of the next).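

In this assay the benzylsulfanyl group gives a 6.7-fold higher number from compound 1 to compound 3 (0.82 log units; beyond the scatter) and so shows, with a second sulfanyl group, the same kind of rise against isobutoxy. On the saturated chain carbon bound to the sulfur, phenyl in place of propyl gives a 1.3-fold higher number from compound 2 to compound 3 (0.10 log units; within the scatter) and so no readable change, which means an added aromatic ring is accepted at this position. No measurement shown accounts for either step. Still open, as far as these compounds go, is whether benzyloxy or an amine here would give a number nearer compound 1 or nearer compounds 2 and 3.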